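Methyl on the Ring Nitrogen of Compound 2

This account rests on a few compounds, and the source may have more. Where it says the series, first, only, none or still open, it means among the compounds named here.

Measured in a functional assay on A549 cells (Homo sapiens) for inhibition, read by sulforhodamine B assay, with a stated time of 72 h; a higher number here means a weaker inhibitor of growth, a lower number a stronger inhibitor of growth:
Compound 1 `CN1CCN(C(=O)/C=C/c2ccncc2-c2ccc3ccccc3c2)CC1`: > 10000 nM (a limit of the assay)
Compound 2 `CCOC(=O)/C=C/c1ccncc1-c1ccc2[nH]ccc2c1`: 7440 nM
Compound 3 `Cn1ncc2cc(-c3cnccc3/C=C/C(=O)O)ccc21`: > 10000 nM (a limit of the assay)

Among these three, compound 2 at 7440 nM is the only one that gives an actual number. The entries for compound 1 and compound 3 are limits of the assay. The next compound, compound 4 `CCOC(=O)/C=C/c1ccncc1-c1ccc2c(ccn2C)c1`, is made from compound 2 by one change, methyl in place of hydrogen on an aromatic nitrogen. Among the measured compounds shown here, no measured pair shows this change, so the only anchor is compound 2 at 7440 nM. In this assay the expected result, a 1.2-fold lower number from compound 2 to compound 4 (0.09 log units; within the scatter), is no shift beyond the usual scatter. For compound 4 the estimated value is 6000 nM, with an expected range of 2500 nM to 10000 nM.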

Compound 4, concentration for 50% growth inhibition: 1720 nM
Compound 4: middle estimate off by 3.5-fold (0.54 log units), on the high side, and the stated range ends above it.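

In this assay, among the compounds shown here, methyl in place of hydrogen on an aromatic nitrogen gives a 4.3-fold lower number from compound 2 to compound 4 (0.64 log units; beyond the scatter), the first step in this set that can be read. It shows that this nitrogen of the five-membered aromatic ring need not carry a hydrogen for growth inhibition, and that a single added carbon there can move the number beyond the scatter. Comparisons remain few: the limit of > 10000 nM in this assay, at which 2 of the 4 values shown sit.

From the compounds shown here alone, what remains open is whether a longer chain, such as ethyl, would lower the number further on this nitrogen. Whether a chain ending in an amine or a carboxylic acid would be tolerated there is also unknown.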